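Swapping trifluoromethoxy for fluoro on a histamine H2 ligand

The compounds below may be only part of what the source reports. "The series", "measured", "known", "first", "only" and "open" are said of these compounds alone.

Measured compounds:
- compound 1, `Cc1nc(N)sc1CCCN/C(N)=N/C(=O)NC(C)c1ccc(OC(F)(F)F)cc1`: 126 nM
- compound 2, `CCCCCCNC(=O)/N=C(\N)NCCCc1sc(N)nc1C`: 28.8 nM

Both compounds were tested in an assay on membranes from Sf9 cells for displacement of a labelled ligand from histamine H2 receptor (Homo sapiens), read by scintillation counting, with a stated time of 60 min; a higher number here means a weaker inhibitor, a lower number a stronger inhibitor. Compound 1 gives the higher of the two numbers, 126 nM, and is therefore the weaker inhibitor of this pair. Compound 2, which carries a plain hexyl chain on the urea instead of the branched aryl-bearing side arm, gives 28.8 nM, a gap that lies beyond the usual scatter of repeated measurements. The two structures differ in more than one place, so nothing can be said about which part of that difference matters.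

Compound 3, `Cc1nc(N)sc1CCCN/C(N)=N/C(=O)NC(C)c1ccc(F)cc1`, keeps the whole shared core of compound 1 and changes only the group on the six-membered aromatic ring of carbon only: fluoro in place of trifluoromethoxy on an aromatic carbon. Among the compounds with values here, no pair of measured compounds shows what such a swap does here, so the direction of the step is open. The most reasonable expectation for compound 3 is a step of about a 1.4-fold higher number from compound 1 to compound 3 (0.15 log units; within the scatter), small and possibly within the scatter. Compound 3 is thus estimated to give 180 nM in this assay, in a range from 60 nM to 550 nM.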

Compound 3, inhibition constant: 31.6 nM
Compound 3: middle estimate off by 5.7-fold (0.76 log units), on the high side; the measured number lies below the stated range.
By their numbers in this assay, from the lowest: compounds 2 and 3 (each within the scatter of the next); then compound 1.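

In this assay this place on the six-membered aromatic ring of carbon only clearly responds to what sits on it. Fluoro in place of trifluoromethoxy brings a 4.0-fold lower number from compound 1 to compound 3 (0.60 log units; beyond the scatter) and gives the first direct reading of a single change among these compounds. The stronger inhibitor carries the group with one heavy atom rather than five and without the hydrogen-bond acceptor counted for trifluoromethoxy, but this one step cannot show which of those differences matters, and no measurement offered here accounts for the step.

The compounds shown leave open whether the oxygen, the three fluorines or simply the number of atoms accounts for the change, and a methoxy group, a chloro group or a plain hydrogen at this place would help to separate these possibilities. They also leave open how the same place would respond to an amine or a carboxylic acid, and whether a longer chain such as butoxy would bring the number back up or lower it further.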